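The source may hold more compounds than are shown below. What is called first, only, known or untested is meant among the compounds shown, and "the series" means these compounds.

Measured in a functional assay on HT-29 cells (Homo sapiens) for cytotoxicity, read by MTT assay, with a stated time of 72 h; on this read-out higher numbers stand for weaker inhibition and lower numbers for stronger inhibition:

- compound 1 (`CN1C/C(=C\c2ccccc2F)C(=O)/C(=C/c2ccccc2F)C1`) gives 2200 nM
- compound 2 (`CN1C/C(=C\c2ccc(F)c(F)c2)C(=O)/C(=C/c2ccc(F)c(F)c2)C1`) gives 1500 nM
- compound 3 (`CN1C/C(=C\c2cc(F)c(F)cc2F)C(=O)/C(=C/c2cc(F)c(F)cc2F)C1`) gives 840 nM

Compound 1 holds the highest number of the three, but only just: its value and that of compound 2 lie within the scatter of each other. Compound 3 alone stands lower than compound 1 by more than the scatter. Among the compounds with values here, these three compounds differ from one another in more than one place, so no single-place step has been measured among them.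

The next compound to be measured is compound 4 (`CCN1C/C(=C\c2ccccc2F)C(=O)/C(=C/c2ccccc2F)C1`), which keeps the core of compound 1 and changes it in one place only: methyl in place of hydrogen on a saturated chain carbon bound to an amine nitrogen in a ring. Read one bond further out, this is methyl to ethyl. Within the data shown here, nothing measured so far speaks directly to this change, so the expectation starts from compound 1 at 2200 nM and assumes little movement. In this assay no step beyond the scatter is expected, and no firm direction can be given. The estimated change is a step of a 1.2-fold lower number from compound 1 to compound 4 (0.06 log units; within the scatter), which is expected to stay within the scatter. The expected value for compound 4 is 1900 nM, with an estimated range from 800 nM to 4500 nM.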

Compound 4, half-maximal inhibitory concentration: 5200 nM
The estimate for compound 4 lay 2.7-fold (0.44 log units) below the measured number; measured number outside the range, above it.
By their numbers in this assay, from the lowest: compounds 3, 2 and 1 (each within the scatter of the next, the first and the last beyond it); then compound 4.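

In this assay the move from methyl to ethyl gives a 2.4-fold higher number from compound 1 to compound 4 (0.37 log units; beyond the scatter) and so provides the only single-place step among the compounds shown. Within the data shown here, it shows that this place, a saturated chain carbon bound to an amine nitrogen in a ring, is not indifferent to change: a single added methyl moves the number beyond the scatter, towards weaker inhibition, which the earlier compounds could not show because they differ from one another only in more than one place. No measurement at hand bears on what lies behind this step.

Resting on one pair, the result leaves open whether a longer chain such as propyl, or a benzyl group, in the same place would raise the number further, hold it or lower it, and whether a bare hydrogen on the ring nitrogen would lie on the other side of compound 1. It also leaves open whether the same change would have a similar size on the core of compound 2 or compound 3, since this step has been read only on the core of compound 1.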